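The source may hold more compounds than are shown below. What is called first, only, known or untested is meant among the compounds shown, and "the series" means these compounds.

Of the compounds shown here, three built on one shared core have been tested in a functional assay on HeLa cells (Homo sapiens) for cytotoxicity, read by WST assay, with a stated time of 48 h; a lower number here means a stronger inhibitor, a higher number a weaker inhibitor. Compound 1 `COc1cccc(/C=C/C[C@@H]2C[C@@H]([C@@H](O)c3ccc(OC)c(OC)c3)CO[C@H]2c2ccc(OC)c(OC)c2)c1` gives 16400 nM in this assay. Compound 2 `COc1ccc(/C=C/C[C@@H]2C[C@@H]([C@@H](O)c3ccc(OC)c(OC)c3)CO[C@H]2c2ccc(OC)c(OC)c2)cc1OC` gives 30600 nM, and compound 3 `COc1cccc([C@H](O)[C@H]2CO[C@@H](c3ccc(OC)c(OC)c3)[C@H](C/C=C/c3ccc(OC)c(OC)c3)C2)c1` gives 18600 nM. Compound 2 thus holds the highest of the three numbers, but both other compounds lie within the usual scatter of it, so the three cannot be ranked against each other.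

Compound 4 `COc1ccc(/C=C/C[C@@H]2C[C@@H]([C@@H](O)c3ccc(OC)c(OC)c3)CO[C@H]2c2ccc(OC)c(OC)c2)cc1` has not yet been measured. Relative to compound 2 it differs in a single place: hydrogen in place of methoxy on an aromatic carbon. Cut one bond further out, the change reads 3,4-dimethoxyphenyl to 4-methoxyphenyl on the 2-(3,4-dimethoxyphenyl)ethenyl arm.

Going by the values given here, two measured steps bear on this. The step of a 1.9-fold higher number from compound 1 to compound 2 (0.27 log units; within the scatter) touched the same ring, putting a methoxy group in place of hydrogen, and stayed within the scatter. The step of a 1.6-fold lower number from compound 2 to compound 3 (0.22 log units; within the scatter) put hydrogen in place of a methoxy group on another ring and also stayed within the scatter. Neither step shows the number of methoxy groups on these rings moving this assay beyond its scatter. For compound 4 the expected step is therefore a 1.4-fold lower number from compound 2 to compound 4 (0.14 log units; within the scatter), that is, no change beyond the scatter. Compound 4 is estimated at 22000 nM, with a range from 10000 nM to 45000 nM.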

Compound 4, half-maximal inhibitory concentration: 17100 nM
Compound 4: middle estimate off by 1.3-fold (0.11 log units), on the high side; low and high end bracket the measured number.
By their numbers in this assay, from the lowest: compounds 1, 4, 3 and 2 (each within the scatter of the next).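

In this assay, taking one methoxy off the 3,4-dimethoxyphenyl ring to leave a 4-methoxyphenyl ring gives a small change (a 1.8-fold lower number from compound 2 to compound 4 (0.25 log units; within the scatter)), so this methoxy group can go without moving the number beyond the scatter. Moving the single methoxy group on this ring from one carbon to another, with 4-methoxyphenyl in place of 3-methoxyphenyl, also makes no difference that can be read (a 1.0-fold higher number from compound 1 to compound 4 (0.02 log units; within the scatter)), so on this evidence neither the number of methoxy groups on this ring, one or two, nor the carbon that carries a single one has a measurable effect. No measurement shown here speaks to why these changes leave the number within the scatter.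

All of these compounds carry only methoxy groups on this ring, so it remains open whether a bare phenyl ring, or one bearing an amine or a carboxylic acid, would move the number beyond the scatter. From the compounds shown here alone, it is equally open whether a longer chain in place of the 2-(4-methoxyphenyl)ethenyl arm would change the number in this assay.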